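Swapping a Halogen on the Anilide Ring

The source may hold more compounds than are shown below. What is called first, only, known or untested is meant among the compounds shown, and "the series" means these compounds.

Three compounds have been tested in a functional assay on HCT-116 cells (Homo sapiens) for inhibition, read by colorimetric assay, with a stated time of 3 days; on this read-out higher numbers stand for weaker inhibition and lower numbers for stronger inhibition:
compound 1 `O=C(CCCCCCNC(=O)C(O)(O)C(F)(F)F)Nc1nc2ccccc2s1` gives 2370 nM
compound 2 `COc1ccccc1NC(=O)CCCCCCNC(=O)C(O)(O)C(F)(F)F` gives 10100 nM
compound 3 `O=C(CCCCCCNC(=O)C(O)(O)C(F)(F)F)Nc1ccc(Cl)cc1` gives 4230 nM

Compound 3 holds the second highest of these three numbers. Two measured steps lead to it: a 1.8-fold higher number from compound 1 to compound 3 (0.25 log units; within the scatter) and a 2.4-fold lower number from compound 2 to compound 3 (0.38 log units; beyond the scatter). Compound 4 `O=C(CCCCCCNC(=O)C(O)(O)C(F)(F)F)Nc1ccc(F)cc1` differs from compound 3 only by fluoro in place of chloro on an aromatic carbon. Among the measured compounds shown here, none of the measured steps swaps one halogen for another; each replaces the whole group on the amide-type nitrogen, and even those moves ranged only from within the scatter to modest. A change of a single atom is therefore expected to give no step beyond the scatter, a 1.2-fold higher number from compound 3 to compound 4 (0.07 log units; within the scatter). Compound 4 is estimated at 5000 nM, within 2500 nM to 12000 nM.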

Compound 4, half-maximal inhibitory concentration: 7570 nM
Compound 4: middle estimate off by 1.5-fold (0.18 log units), on the low side; the range from low to high includes it.
By their numbers in this assay, from the lowest: compounds 1, 3, 4 and 2 (each within the scatter of the next, the first and the last beyond it).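

In this assay, the single-atom swap on this aromatic carbon gives a 1.8-fold higher number from compound 3 to compound 4 (0.25 log units; within the scatter), so chloro and fluoro cannot be told apart here. Compound 4 also cannot be separated from the 2-methoxyphenyl compound, with a 1.3-fold lower number from compound 2 to compound 4 (0.13 log units; within the scatter), yet it does separate from the 1,3-benzothiazol-2-yl compound, with a 3.2-fold higher number from compound 1 to compound 4 (0.50 log units; beyond the scatter), a gap that the chloro compound did not reach. Nothing measured here explains these numbers.

Still open, on these data alone, is how bromo or an amine on the same aromatic carbon would read. A longer chain between the two amide groups is also untested in these compounds.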